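Capping the aromatic hydroxy of compound 2

The source may report more compounds than this note shows. Statements on the series, on what has been measured and on what is new or still open speak of the compounds shown alone.

Compound 1 `Cc1c(C)c2c(c(C)c1OC(=O)CCC(=O)O)CCC(C)(C(=O)NCC1CC(C)(C)N([O])C1(C)C)O2`: > 300000 nM (a limit)
Compound 2 `Cc1c(C)c2c(c(C)c1O)CCC(C)(C(=O)NC1CC(C)(C)N([O])C1(C)C)O2`: 58000 nM

Within the data shown here, only two compounds have been tested so far, and only one of them has given a true number. In a functional assay on MCF7 cells (Homo sapiens) for cytotoxicity, read by MTT assay, with a stated time of 72 h (a higher number here means a weaker inhibitor, a lower number a stronger inhibitor), compound 2 gives 58000 nM as that single number, so it has no measured neighbour to be ranked against.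

Compound 3 `Cc1c(C)c2c(c(C)c1OC(=O)CCC(=O)O)CCC(C)(C(=O)NC1CC(C)(C)N([O])C1(C)C)O2` changes compound 2 in one place: (2-carboxyethyl)carbonyl in place of hydrogen on an oxygen on an aromatic ring. In words, a (2-carboxyethyl)carbonyl group takes the place of hydrogen on an oxygen on an aromatic ring, turning hydroxy into ((2-carboxyethyl)carbonyl)oxy.

Compound 1 also carries this group. A weaker inhibitor is expected in compound 3 because compound 1 gives > 300000 nM, which is a limit of the assay. This expectation rests on that one compound alone. The estimated change is a 2.8-fold higher number from compound 2 to compound 3 (0.44 log units; beyond the scatter) and this expected step could well end in a limit too. The expected result in this assay for compound 3 is an estimated 160000 nM (range 60000 nM to 300000 nM).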

Compound 3, half-maximal inhibitory concentration: > 300000 nM
Compound 3: only a limit was reported; the forecaster's own chance of this, stated with the estimate: 45%; middle value at least 1.8-fold (0.27 log units) away from the limit.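

On the shared core, putting a (2-carboxyethyl)carbonyl group in place of the hydrogen on the oxygen, which turns hydroxy into ((2-carboxyethyl)carbonyl)oxy, gives in this assay an at least 5.1-fold higher number from compound 2 to compound 3 (0.71 log units; beyond the scatter). Among these compounds, this is the first comparison in which that change stands alone, and it shows that capping the hydroxy of compound 2 in this way gives a weaker inhibitor, by more than the usual scatter. Compound 1 carries the same group but also differs from compound 2 in the group on the amide-type nitrogen, so it could not show this by itself, and the true size of the new step, like the step between compound 1 and compound 3, cannot be read because the values are cut off by the assay: the limit of > 300000 nM in this assay, at which 2 of the 3 values shown sit.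

The compounds shown leave open whether the loss comes from covering the hydroxy at all or from this particular group, a question that a small acetyl ester or a methyl ether on the same oxygen would help to settle. They also leave open what the carboxylic acid at the end of the chain contributes, which an ester chain ending in a plain methyl group would test.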